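From Isopropoxy to Isopropylamino on the Carbonyl Carbon

A few compounds are considered here, and "the series" means these few. Any claim that something is new, unique, unknown or untested is made for them only; others in the source may bear on it.

Compound 3 `CCc1cc(S(=O)(=O)N2C[C@H](c3ccccc3)NC2=O)ccc1NC(=O)OC(C)C` gives 60 nM in a functional assay on NCI-H460 cells (Homo sapiens) for cytotoxicity, read by MTT assay; a higher number here means a weaker inhibitor, a lower number a stronger inhibitor. It stands level with compound 1 `CCCOC(=O)Nc1ccc(S(=O)(=O)N2C[C@H](c3ccccc3)NC2=O)cc1CC`, which gives 60 nM, and together they hold the lowest numbers of the three measured. Compound 2 `CCc1cc(S(=O)(=O)N2C[C@H](c3ccccc3)NC2=O)ccc1NC(=O)c1ccc(N)cc1` gives 670 nM, and the step of an 11-fold lower number from compound 2 to compound 3 (1.05 log units; beyond the scatter) is large. Compound 4 `CCc1cc(S(=O)(=O)N2C[C@H](c3ccccc3)NC2=O)ccc1NC(=O)NC(C)C` differs from compound 3 by isopropylamino in place of isopropoxy on a carbonyl carbon. Among the measured compounds shown here, two measured steps bear on this position: an 11-fold higher number from compound 1 to compound 2 (1.05 log units; beyond the scatter) was large, while no change at the digits printed from compound 1 to compound 3 (within the scatter) stayed within the scatter, so the group on the carbonyl carbon matters more than the alkyl chain attached to it. With the isopropyl chain kept, compound 4 is expected to show at most a small shift, a 1.5-fold higher number from compound 3 to compound 4 (0.18 log units; within the scatter). Compound 4 is estimated at 90 nM, with a range from 30 nM to 300 nM.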

Compound 4, half-maximal inhibitory concentration: 70 nM
Beside the measured number, compound 4's estimate is 1.3-fold (0.11 log units) above it; the range from low to high includes it.
By their numbers in this assay, from the lowest: compounds 1, 3 and 4 (each within the scatter of the next); then compound 2.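

Isopropylamino can take the place of isopropoxy on the carbonyl carbon without the number leaving the scatter (a 1.2-fold higher number from compound 3 to compound 4 (0.07 log units; within the scatter)), and the comparison with the propoxy group reads the same way (a 1.2-fold higher number from compound 1 to compound 4 (0.07 log units; within the scatter)). So the earlier finding that the alkyl chain could vary without a clear effect now extends to the atom joining that chain to the carbonyl carbon, oxygen or nitrogen. The 4-aminophenyl group remains apart from this one (a 9.6-fold lower number from compound 2 to compound 4 (0.98 log units; beyond the scatter)). Nothing available explains why isopropoxy and isopropylamino read alike. As far as these compounds go, whether a longer chain or a dimethylamino group on the carbonyl carbon would read the same remains open.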